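Aryl swaps on the sulfonyl group of a shared core

The source may hold more compounds than are shown below. What is called first, only, known or untested is meant among the compounds shown, and "the series" means these compounds.

compound 1, `COc1cc2nc(N3CCN(S(=O)(=O)c4ccccc4[N+](=O)[O-])CC3)nc(N)c2cc1OC`: 35000 nM
compound 2, `COc1cc2nc(N3CCN(S(=O)(=O)c4cccc([N+](=O)[O-])c4)CC3)nc(N)c2cc1OC`: 32000 nM
compound 3, `COc1cc2nc(N3CCN(S(=O)(=O)c4ccc(C(F)(F)F)cc4)CC3)nc(N)c2cc1OC`: 27000 nM

In a functional assay on PC-3 cells (Homo sapiens) for inhibition (on this read-out higher numbers stand for weaker inhibition and lower numbers for stronger inhibition), the three measured compounds share one core and differ only in the aryl group on the sulfonyl sulfur. Compound 3 gives the lowest of the three numbers, yet the steps of a 1.3-fold lower number from compound 1 to compound 3 (0.11 log units; within the scatter) and a 1.2-fold lower number from compound 2 to compound 3 (0.07 log units; within the scatter) lie within the scatter, as does a 1.1-fold lower number from compound 1 to compound 2 (0.04 log units; within the scatter), so the three compounds read alike in this assay.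

Compound 4, `COc1cc2nc(N3CCN(S(=O)(=O)c4ccc(-c5ccc(C(F)(F)F)cc5)cc4)CC3)nc(N)c2cc1OC`, differs from compound 3 by 4-(trifluoromethyl)phenyl in place of trifluoromethyl on an aromatic carbon. Among the compounds with values here, no measured step makes a change of this kind: each of them exchanges one aryl group for another on the same sulfur, and each stays within the scatter. The measured steps therefore give no ground to expect movement beyond the scatter in this assay for this larger change. The estimated step is no change at the digits printed from compound 3 to compound 4 (within the scatter). Compound 4 is thus expected to give about 27000 nM, with a range from 10000 nM to 75000 nM.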

Compound 4, half-maximal inhibitory concentration: 3300 nM
Compound 4: the middle estimate sits 8.2-fold (0.91 log units) above what was measured; the whole stated range lies above it.
By their numbers in this assay, from the lowest: compound 4; then compounds 3, 2 and 1 (each within the scatter of the next).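

In this assay, replacing trifluoromethyl with 4-(trifluoromethyl)phenyl on this aromatic carbon gives an 8.2-fold lower number from compound 3 to compound 4 (0.91 log units; beyond the scatter), the only step among the compounds shown that lies beyond the scatter. The aryl group on the sulfonyl sulfur is therefore not a silent part of the series: exchanging one substituted phenyl for another in compounds 1, 2 and 3 left the numbers alike, whereas this added aromatic ring, with trifluoromethyl carried on it, separates compound 4 from the rest. Nothing measured here bears on why the number falls.

As far as these compounds go, it remains open whether the step comes from the added ring alone or needs the trifluoromethyl on it, a question a plain phenyl at this place would address. From the compounds shown here alone, how an amine or a carboxylic acid on the added ring would read in this assay also remains open.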